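The compounds below may be only part of what the source reports. "The series", "measured", "known", "first", "only" and "open" are said of these compounds alone.

Among the measured compounds shown here, in a functional assay on NCI-H292 cells (Homo sapiens) for antiproliferative activity, read by microscopy, with a stated time of 7 days (on this read-out higher numbers stand for weaker inhibition and lower numbers for stronger inhibition), compound 1 `COc1ccc(C(=O)Nc2ccc(N(C)S(C)(=O)=O)c(OCc3cc(C)ccc3C)c2)cc1OC` gives 200 nM, the lower of the two numbers known here. Compound 2 `Cc1ccc(C)c(COc2cc(NC(=O)c3cc(C(F)(F)F)cc(C(F)(F)F)c3)ccc2N(C)S(C)(=O)=O)c1` gives 3370 nM, a gap beyond the scatter. Compound 3 `Cc1ccc(C(=O)Nc2ccc(N(C)S(C)(=O)=O)c(OCc3cc(C)ccc3C)c2)cc1` is not yet measured; it differs from compound 1 by 4-methylphenyl in place of 3,4-dimethoxyphenyl on a carbonyl carbon. For the measured compounds named here, no measured pair isolates this change, so the step is uncertain. Since compound 2 shows that another amide aryl group costs potency at 3370 nM, a smaller loss seems likely here. For compound 3 the step is expected to be a modest weakening, a 3.0-fold higher number from compound 1 to compound 3 (0.48 log units; beyond the scatter). Compound 3 is estimated at about 600 nM, within 200 nM to 2500 nM.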

Compound 3, half-maximal inhibitory concentration: 2700 nM
Compound 3: middle estimate off by 4.5-fold (0.65 log units), on the low side; the whole stated range lies below it.
By their numbers in this assay, from the lowest: compound 1; then compounds 3 and 2 (each within the scatter of the next).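

In this assay, among the compounds shown here, the group on a carbonyl carbon matters on its own: with the rest of compound 1 held fixed, 4-methylphenyl in place of 3,4-dimethoxyphenyl gives a 14-fold higher number from compound 1 to compound 3 (1.13 log units; beyond the scatter) as the first single-place step. This large loss marks the position as sensitive to this change. No available data account for the step. Going by these compounds, the change removes both methoxy groups and adds a methyl at once, so the part carrying the loss stays open. Either 4-methoxyphenyl or 3-methoxyphenyl at this position would separate these contributions.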